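A few compounds are considered here, and "the series" means these few. Any claim that something is new, unique, unknown or untested is made for them only; others in the source may bear on it.

Working notes on the series in an assay on isolated protein for inhibition of NADPH oxidase 4 (Homo sapiens), read by chemiluminescence, in the presence of a further agent that is not named here; on this read-out lower numbers stand for stronger inhibition and higher numbers for weaker inhibition.

Three compounds share one core and differ in the amino group on the aryl ring. Compound 1 `COc1cc(N(C)CCCO)ccc1/C=C1\C(=O)N(c2ccccc2)C(=S)N1C` gives 2480 nM. Compound 2 `CN1C(=S)N(c2ccccc2)C(=O)/C1=C\c1ccc(N(C)C)cc1O` gives 3430 nM. Going by the values given here, compound 3 `CCN(CC)c1ccc(/C=C2\C(=O)N(c3ccccc3)C(=S)N2C)c(O)c1` gives 1100 nM, the lowest number of the three; the step from compound 2 a 3.1-fold lower number from compound 2 to compound 3 (0.49 log units; beyond the scatter) is the only single-point step measured so far.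

Compound 4 `CN1C(=S)N(c2ccccc2)C(=O)/C1=C\c1ccc(N(C)CCCO)cc1O` is not yet measured. It follows from compound 3 by (3-hydroxypropyl)(methyl)amino in place of diethylamino on an aromatic carbon. Among the compounds with values here, no measured step bears on this exact change. The nearest reference is compound 1, which already carries the entering (3-hydroxypropyl)(methyl)amino group, though with a methoxy group rather than the hydroxy group of compound 4; compound 1 sits at 2480 nM, above compound 3. The step of a 3.1-fold lower number from compound 2 to compound 3 (0.49 log units; beyond the scatter) shows that the amino substituent on this ring can move the number by a modest amount, and going from diethylamino to a group with a hydrogen-bond donor is a change of comparable size in the other direction.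

For compound 4 the expected step is a 2.1-fold higher number from compound 3 to compound 4 (0.32 log units; beyond the scatter), a modest rise. The estimate for compound 4 in this assay is 2300 nM, with a range from 1100 nM to 4800 nM.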

Compound 4, half-maximal inhibitory concentration: 5020 nM
For compound 4 the middle estimate is 2.2-fold (0.34 log units) below the measured one, outside the stated range (above it).
By their numbers in this assay, from the lowest: compound 3; then compounds 1, 2 and 4 (each within the scatter of the next, the first and the last beyond it).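

In this assay, with the hydroxy group in place, exchanging the diethylamino group for (3-hydroxypropyl)(methyl)amino gives a 4.6-fold higher number from compound 3 to compound 4 (0.66 log units; beyond the scatter), larger than the drop gained earlier on going from dimethylamino to diethylamino, so among compound 2, compound 3 and compound 4 only the diethylamino group stands apart. The 2-hydroxyethyl extension on the saturated chain carbon separates nothing, since the comparison gives a 1.5-fold higher number from compound 2 to compound 4 (0.17 log units; within the scatter) and the dimethylamino and (3-hydroxypropyl)(methyl)amino groups cannot be told apart in this read-out. The oxygen on the ring now has its first single-point reading: with the (3-hydroxypropyl)(methyl)amino group held constant, hydrogen in place of methyl gives a 2.0-fold higher number from compound 1 to compound 4 (0.31 log units; beyond the scatter), so the methoxy compound 1 has the lower number of this pair.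

Nothing available gives a reason for any of these steps. Going by these compounds, whether the oxygen step carries over to the diethylamino group remains open, as does how a dipropylamino group or a 3-methoxypropyl chain on the nitrogen would read against diethylamino.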